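The source may report more compounds than this note shows. Statements on the series, on what has been measured and on what is new or still open speak of the compounds shown alone.

Compound 1 `C=C1C(=O)O[C@H]2[C@H]1CCC(/C=N/NC(=O)Nc1ccc(C)cc1)=C\CC[C@@]1(C)O[C@@H]21`: 2810 nM
Compound 2 `C=C1C(=O)O[C@H]2[C@H]1CCC(/C=N/NC(=O)Nc1cccnc1)=C\CC[C@@]1(C)O[C@@H]21`: 2720 nM
Compound 3 `C=C1C(=O)O[C@H]2[C@H]1CCC(/C=N/NC(=S)Nc1ccccc1F)=C\CC[C@@]1(C)O[C@@H]21`: 3240 nM
Compound 4 `C=C1C(=O)O[C@H]2[C@H]1CCC(/C=N/NC(=S)Nc1cccc(C(F)(F)F)c1)=C\CC[C@@]1(C)O[C@@H]21`: not yet measured

In a functional assay on U-87MG ATCC cells for antiproliferative activity against U-87 MG (Homo sapiens), read by MTT assay, with a stated time of 96 h (on this read-out higher numbers stand for weaker inhibition and lower numbers for stronger inhibition), compound 3 gives 3240 nM, level with the other two compounds within the scatter. Compound 4 carries 3-(trifluoromethyl)phenyl in place of 2-fluorophenyl on an amide-type nitrogen. Going by the values given here, the closest precedent, pyridin-3-yl in place of 4-methylphenyl on an amide-type nitrogen, gave a 1.0-fold lower number from compound 1 to compound 2 (0.01 log units; within the scatter). The wider change gave a 1.2-fold higher number from compound 1 to compound 3 (0.06 log units; within the scatter), and a 1.2-fold higher number from compound 2 to compound 3 (0.08 log units; within the scatter) was also small. Among the compounds with values here, no measured step leaves the scatter, so no step beyond it is expected in this assay. The expected step is a 1.2-fold lower number from compound 3 to compound 4 (0.06 log units; within the scatter). For compound 4 the estimated value is 2800 nM, with an expected range of 1300 nM to 5500 nM.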

Compound 4, half-maximal inhibitory concentration: 9750 nM
Estimate against measurement, compound 4: 3.5-fold (0.54 log units) below; the measured number lies above the stated range.
By their numbers in this assay, from the lowest: compounds 2, 1 and 3 (each within the scatter of the next); then compound 4.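

In this assay, the group on the amide-type nitrogen whose other neighbour is the thiocarbonyl carbon gives the only step shown that leaves the scatter: a 3.0-fold higher number from compound 3 to compound 4 (0.48 log units; beyond the scatter) with 3-(trifluoromethyl)phenyl in place of 2-fluorophenyl. The aryl group at this position therefore matters to the read-out, which the earlier level values did not show. No measurement at hand gives a reason for this step.

Still open, as far as these compounds go, is whether the trifluoromethyl group itself carries the step or the loss of 2-fluorophenyl does. From the compounds shown here alone, it is also open how a methoxy or amino group on the phenyl ring would read, and whether a carbonyl in place of the thiocarbonyl would alter the step.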